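A few compounds are considered here, and "the series" means these few. Any claim that something is new, unique, unknown or untested is made for them only; others in the source may bear on it.

- Compound 1 `Nc1ncnn2c([C@@H]3O[C@H](CO)[C@@H](O)[C@H]3O)cc(C#Cc3ccc(F)cc3)c12`: 79400 nM
- Compound 2 `Nc1ncnn2c([C@@H]3O[C@H](CO)[C@@H](O)[C@H]3O)cc(-c3ccc(F)cc3F)c12`: 93300 nM

In a functional assay on NCI-H460 cells (Homo sapiens) for antiproliferative activity, with a stated time of 72 h (on this read-out lower numbers stand for stronger inhibition and higher numbers for weaker inhibition), compound 2 gives 93300 nM, which cannot be told apart from the value of compound 1. Compound 3 `Nc1ncnn2c([C@@H]3O[C@H](CO)[C@@H](O)[C@H]3O)cc(-c3ccoc3)c12` carries furan-3-yl in place of 2,4-difluorophenyl on an aromatic carbon. For the measured compounds named here, the only measured step, a 1.2-fold higher number from compound 1 to compound 2 (0.07 log units; within the scatter), lies within the scatter, but no measured compound has a five-membered aromatic ring at this place, so it is a weak guide. A modest move to stronger inhibition is expected, with real uncertainty, as a 4.7-fold lower number from compound 2 to compound 3 (0.67 log units; beyond the scatter). For compound 3 the estimated value is 20000 nM, with an expected range of 500 nM to 100000 nM.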

Compound 3, half-maximal inhibitory concentration: 1500 nM
Estimate against measurement, compound 3: 13-fold (1.12 log units) above; the range from low to high includes it.
By their numbers in this assay, from the lowest: compound 3; then compounds 1 and 2 (each within the scatter of the next).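

In this assay, the group at this place clearly matters: furan-3-yl in place of 2,4-difluorophenyl gives a large drop in the number (a 62-fold lower number from compound 2 to compound 3 (1.79 log units; beyond the scatter)), and furan-3-yl in place of 2-(4-fluorophenyl)ethynyl gives a similar one (a 53-fold lower number from compound 1 to compound 3 (1.72 log units; beyond the scatter)). The two earlier groups could not be told apart, so they gave no hint of this sensitivity. Nothing available explains the stronger inhibition. Still open, going by these compounds, is whether the furan ring itself is needed, or whether thiophene, pyrrole, an amine or a short alkyl chain would serve equally well.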